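The source may report more compounds than this note shows. Statements on the series, on what has been measured and on what is new or still open speak of the compounds shown alone.

Compound 1 `Clc1cccc(-c2cc(-c3ccc(Cl)o3)cc(-c3cccs3)n2)c1` gives 12800 nM in a functional assay on HeLa cells (Homo sapiens) for cytotoxicity, in the presence of a further agent that is not named here; on this read-out lower numbers stand for stronger inhibition and higher numbers for weaker inhibition.
Compound 2 `Clc1cccc(-c2cc(-c3ccc(Cl)o3)cc(-c3ccsc3)n2)c1` gives 8710 nM in this assay.

Among these two numbers, compound 1 has the highest, which on this read-out means the weaker inhibition of the pair; its nearest neighbour is compound 2, and the step of a 1.5-fold lower number from compound 1 to compound 2 (0.17 log units; within the scatter) lies within the scatter, so the two cannot be told apart.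

Compound 3 `Clc1ccc(-c2cc(-c3ccco3)nc(-c3cccs3)c2)o1` has not yet been measured. It differs from compound 1 in one place: furan-2-yl in place of 3-chlorophenyl on an aromatic carbon. The change sits on an aromatic carbon of the shared core, next to the ring nitrogen.

Among the measured compounds shown here, the only measured step, a 1.5-fold lower number from compound 1 to compound 2 (0.17 log units; within the scatter), concerns a different place and a different exchange, thiophen-3-yl in place of thiophen-2-yl, and stayed within the scatter. For the measured compounds named here, no measured step covers a furan-2-yl in place of a 3-chlorophenyl, so there is no basis for expecting a shift in either direction beyond the scatter.

The estimate for compound 3 is therefore 12000 nM, a step of a 1.1-fold lower number from compound 1 to compound 3 (0.03 log units; within the scatter), with a wide range from 3000 nM to 50000 nM, because compound 1 sits at 12800 nM and nothing measured points away from it.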

Compound 3, half-maximal inhibitory concentration: 18800 nM
Beside the measured number, compound 3's estimate is 1.6-fold (0.19 log units) below it, and the stated range covers the measured number.
By their numbers in this assay, from the lowest: compounds 2, 1 and 3 (each within the scatter of the next, the first and the last beyond it).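

Placing furan-2-yl in place of 3-chlorophenyl next to the ring nitrogen gives a 1.5-fold higher number from compound 1 to compound 3 (0.17 log units; within the scatter) in this assay, so this position has now been probed directly, and the two compounds cannot be told apart. The exchange is not a minimal one on paper: 3-chlorophenyl, a six-membered aromatic ring of carbon only with 7 heavy atoms and 0 hydrogen-bond acceptors, gives way to a five-membered aromatic ring with 1 hetero atom, 5 heavy atoms and 1 hydrogen-bond acceptor, and still no difference can be read in this assay. There is no separate measurement that could explain this result.

All the groups shown at this position are aromatic rings, so it remains open whether an amine, a carboxylic acid or a longer alkyl chain there would move the number beyond the scatter. Going by these compounds, it also remains open whether furan-2-yl in place of 3-chlorophenyl would give the same result on a core carrying thiophen-3-yl, the group found in compound 2, rather than thiophen-2-yl.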